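Notes on aryl replacement in the aminothiophene series

The source may report more compounds than this note shows. Statements on the series, on what has been measured and on what is new or still open speak of the compounds shown alone.

Compound 1 `CC(C)(C)Cc1c(-c2ccccn2)sc(N)c1C(=O)c1ccc(Cl)cc1` gives 1% in an assay on CHO cells for displacement of a labelled ligand from adenosine receptor A3 (Homo sapiens), read by scintillation counting, tested at 10 uM; on this read-out higher numbers stand for more inhibition at the one concentration tested (going by the name of the read-out) and lower numbers for less inhibition. Compound 2 `Cc1ccccc1-c1sc(N)c(C(=O)c2ccc(Cl)cc2)c1CC(C)(C)C` gives 1% in this assay, and the step of no change at the digits printed from compound 1 to compound 2 (within the scatter) leaves compound 2 level with compound 1 within the scatter. Compound 3 `CC(C)(C)Cc1c(-c2cn[nH]c2)sc(N)c1C(=O)c1ccc(Cl)cc1` carries the change (1H-pyrazol-4-yl in place of 2-methylphenyl on an aromatic carbon). Among the measured compounds shown here, only the step from compound 1 to compound 2 bears on this change, and it showed nothing beyond the scatter, so for compound 3 no step beyond the scatter is expected in this assay, in either direction. The estimate for compound 3 is therefore 3% (range -8% to 16%), a step of a number 2 percentage points higher from compound 2 to compound 3 (within the scatter) expected to stay within the scatter.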

Compound 3, a percentage reported as inhibition, at one concentration (the size of the read-out at that concentration, not a potency): 1%
Beside the measured number, compound 3's estimate is 2 percentage points above it, within the range that was stated.
By their numbers in this assay, from the lowest: compounds 1, 2 and 3 (each within the scatter of the next).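

In this assay, 1H-pyrazol-4-yl in place of 2-methylphenyl gives no change at the digits printed from compound 2 to compound 3 (within the scatter), and in place of pyridin-2-yl it gives no change at the digits printed from compound 1 to compound 3 (within the scatter). The read-out at this carbon next to the ring sulfur therefore stays level with a five-membered aromatic ring carrying a hydrogen-bond donor, as well as with the two six-membered aromatic rings. No measurement on hand accounts for this flat result.

The compounds shown leave open whether any group here lifts the read-out at all, for instance a carboxylic acid or a saturated ring amine such as morpholine.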